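Hydroxy in place of cyano: compound 2 to compound 3

The source may report more compounds than this note shows. Statements on the series, on what has been measured and on what is new or still open speak of the compounds shown alone.

Compound 1 `COC(=O)CC/C(C)=C/Cc1c(OC)c(C)c2c(c1OCC#CCN1CCCc3ccccc31)C(=O)OC2` gives 18000 nM in a functional assay on A549 cells (Homo sapiens) for inhibition, read by sulforhodamine B assay; a lower number here means a stronger inhibitor, a higher number a weaker inhibitor. Compound 2 `COC(=O)CC/C(C)=C/Cc1c(OC)c(C)c2c(c1OCC#CCN1CCN(c3ccc(C#N)cc3)CC1)C(=O)OC2` reaches only the limit of this assay, > 50000 nM, so no number is known for it and the limit of > 50000 nM in this assay, at which 1 of the 2 values shown sits, is all that can be said. Compound 3 `COC(=O)CC/C(C)=C/Cc1c(OC)c(C)c2c(c1OCC#CCN1CCN(c3ccc(O)cc3)CC1)C(=O)OC2` differs from compound 2 by hydroxy in place of cyano on an aromatic carbon. Going by the values given here, no measured step between compounds with a single difference exists, so the size of this change is open; a step within the usual scatter, or a modest move toward stronger inhibition, seems the likelier outcome. Compound 3 is expected to give 40000 nM, between 15000 nM and 100000 nM. This estimate means a step of an at least 1.2-fold lower number from compound 2 to compound 3 (0.09 log units; that floor lies within the scatter) in this assay.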

Compound 3, half-maximal inhibitory concentration: > 50000 nM
Compound 3: only a limit was reported; the forecaster's own chance of this, stated with the estimate: 55%; at least 1.2-fold (0.09 log units) between middle value and limit.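

No step can be read from compound 2 to compound 3 in this assay: both results are limits of the assay, not numbers. The compounds shown leave open whether hydroxy in place of cyano changes inhibition at all.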